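The source may report more compounds than this note shows. Statements on the series, on what has been measured and on what is new or still open speak of the compounds shown alone.

Going by the values given here, compound 2, `CCNC(=S)N1N=C(c2ccc(C)cc2)CC1c1ccc[nH]1`, is the weaker of the two compounds measured so far in an assay for inhibition of Amine oxidase [flavin-containing] A (Rattus norvegicus), with a stated time of 60 min (on this read-out lower numbers stand for stronger inhibition and higher numbers for weaker inhibition), where compound 2 gives 329000 nM. Its neighbour compound 1, `CNC(=S)N1N=C(c2ccc(C)cc2)CC1c1ccc[nH]1`, gives 295000 nM in this assay; the two numbers sit close together, and the step of a 1.1-fold higher number from compound 1 to compound 2 (0.05 log units; within the scatter) lies within the scatter. Compound 3, `CCCNC(=S)N1N=C(c2ccc(C)cc2)CC1c1ccc[nH]1`, carries the change methyl in place of hydrogen on a saturated chain carbon, two bonds along the chain from an amide-type nitrogen. Among the compounds with values here, the only measured step that bears on this is the one from compound 1 to compound 2, which extended the same chain by one carbon and moved the number by barely anything. Compound 3 is therefore expected to stay within the scatter of compound 2, with a step of a 1.1-fold higher number from compound 2 to compound 3 (0.03 log units; within the scatter). The estimate for compound 3 in this assay is 350000 nM, within a range of 150000 nM to 800000 nM.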

Compound 3, half-maximal inhibitory concentration: 369000 nM
Compound 3: middle estimate off by 1.1-fold (0.02 log units), on the low side, and the stated range covers the measured number.
By their numbers in this assay, from the lowest: compounds 1, 2 and 3 (each within the scatter of the next).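

In this assay the further methyl at this place gives a 1.1-fold higher number from compound 2 to compound 3 (0.05 log units; within the scatter) for the second added carbon, which behaves like the first in staying within the scatter. The whole change from methyl to propyl, read as a 1.3-fold higher number from compound 1 to compound 3 (0.10 log units; within the scatter) and spanning both added carbons, also stays within the scatter, so methyl, ethyl and propyl cannot be told apart at this position in these three compounds. Nothing is available that would explain this flat result.

The compounds shown leave open whether a longer chain such as butyl, a branched chain such as isopropyl, or a chain ending in an amine or a carboxylic acid would move the number beyond the scatter. They also leave open whether a ring such as phenyl at this position would do so.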